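The source may hold more compounds than are shown below. What is called first, only, known or untested is meant among the compounds shown, and "the series" means these compounds.

Working notes on the series. The shared core of compound 1, `O=C(/C=C\Nc1ccc(F)cc1)c1nc(-c2ccc(F)cc2)n2ccccc12`, carries a 4-fluorophenyl on the imidazole part and a (4-fluorophenyl)amino on the enaminone side chain. In a functional assay on A549 cells (Homo sapiens) for cytotoxicity, read by MTT assay, with a stated time of 48 h (on this read-out lower numbers stand for stronger inhibition and higher numbers for weaker inhibition), compound 1 gives 13200 nM, the highest of the two numbers recorded so far. For the measured compounds named here, the only other measured member, compound 2, `COc1ccc(-c2nc(C(=O)/C=C\Nc3ccc4[nH]ccc4c3)c3ccccn23)cc1`, gives 4800 nM in this assay; compound 2 differs from compound 1 in more than one place, so the two values are set side by side here without any step being drawn between them, and they show only that compound 2 has the lower number, beyond the scatter.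

The next compound, compound 3, `COc1ccc(N/C=C\C(=O)c2nc(-c3ccc(F)cc3)n3ccccc23)cc1`, is made from compound 1 by the change (methoxy in place of fluoro on an aromatic carbon), that is, methoxy in place of fluoro on an aromatic carbon. Going by the values given here, no step between measured compounds isolates this change, so the expected size of the step rests on the two values alone. The working expectation is a small step from compound 1 to compound 3 in this assay, a 1.5-fold lower number from compound 1 to compound 3 (0.17 log units; within the scatter), toward a somewhat lower number but not with confidence beyond the scatter. Compound 3 is therefore estimated at 9000 nM, with a range from 3000 nM to 30000 nM.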

Compound 3, half-maximal inhibitory concentration: 19200 nM
Compound 3: middle estimate off by 2.1-fold (0.33 log units), on the low side; the range from low to high includes it.
By their numbers in this assay, from the lowest: compound 2; then compounds 1 and 3 (each within the scatter of the next).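

For the compounds shown here, this is the first step that isolates a single place: in this assay, going from (4-fluorophenyl)amino to (4-methoxyphenyl)amino, with the 4-fluorophenyl on the imidazole part unchanged, gives a 1.5-fold higher number from compound 1 to compound 3 (0.16 log units; within the scatter). At this aromatic carbon, para to a large group, fluoro with its 1 heavy atom and methoxy with its 2 heavy atoms and 1 hydrogen-bond acceptor therefore cannot be told apart by this read-out, so the exchange does not separate the two compounds. No measured evidence bears on this result.

Compound 2 still has the lowest number at 4800 nM, but it differs from compound 1 and compound 3 in more than one place, so that value cannot be assigned to any single part of its structure. On these data alone, it remains open whether a group of another kind at this same aromatic carbon, such as an amine or a carboxylic acid, would move the number beyond the scatter, and whether the same methoxy in place of fluoro on the 4-fluorophenyl of the imidazole part would give a step of similar size.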